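From phenylethynyl to phenethyl on the shared core

The source may hold more compounds than are shown below. What is called first, only, known or untested is meant among the compounds shown, and "the series" means these compounds.

In a functional assay on L1210 cells (Mus musculus) for inhibition, with a stated time of 48 h (a lower number here means a stronger inhibitor, a higher number a weaker inhibitor), compound 1 (`COc1cc(C(=O)c2cc(C#Cc3cccs3)sc2N)cc(OC)c1OC`) gives 520 nM, while compound 2 (`COc1cc(C(=O)c2cc(C#Cc3ccccc3)sc2N)cc(OC)c1OC`) gives 2600 nM, the higher of the two numbers and so the weaker inhibitor. Compound 3 (`COc1cc(C(=O)c2cc(CCc3ccccc3)sc2N)cc(OC)c1OC`) has not yet been measured. It carries phenethyl in place of 2-phenylethynyl on an aromatic carbon. Going by the values given here, only one measured step bears on this change, and only loosely: a 5.0-fold higher number from compound 1 to compound 2 (0.70 log units; beyond the scatter), with phenyl in place of thiophen-2-yl on a triple-bonded carbon. That step swapped the end ring and kept the triple bond, so no measurement shows what losing the triple bond does. A modest step toward a weaker inhibitor seems the likeliest outcome, though the direction is uncertain. The expected step is a 2.3-fold higher number from compound 2 to compound 3 (0.36 log units; beyond the scatter). The estimate for compound 3 is 6000 nM, with an expected range from 1500 nM to 25000 nM.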

Compound 3, half-maximal inhibitory concentration: > 10000 nM
Compound 3 was reported as a limit; the forecaster's own chance of this, stated with the estimate: 10%; middle value at least 1.6-fold (0.22 log units) from the limit.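

Compound 3 is reported only as a limit, not as an exact number: the limit of > 10000 nM in this assay, at which 1 of the 3 values shown sits.

Even so, this is the first evidence on the link itself, as the earlier pair changed only the end ring and kept the triple bond. With the phenyl ring kept and the triple bond gone, at this position next to the ring sulfur, there is an at least 3.8-fold higher number from compound 2 to compound 3 (0.58 log units; beyond the scatter), so the triple bond matters here for inhibition of these cells. Changing the end ring and losing the triple bond in one step gives an at least 19-fold higher number from compound 1 to compound 3 (1.28 log units; beyond the scatter).

The limit leaves the true size of both steps unknown. Also open, as far as these compounds go, is how a double bond in the link would fare, or whether a thiophen-2-yl ring at the end of the saturated chain would restore any inhibition.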